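Benzyloxy variations in the antiproliferative series

This account rests on a few compounds, and the source may have more. Where it says the series, first, only, none or still open, it means among the compounds named here.

Among the measured compounds shown here, compound 2 `Cc1cc(C)cc(COc2ccc(-c3cc(CN4CCN(Cc5ccc(C(F)(F)F)cc5)CC4)no3)cc2)c1` holds the lowest number of the two measured so far in a functional assay on MCF7 cells (Homo sapiens) for antiproliferative activity, read by sulforhodamine B assay, with a stated time of 72 h (a lower number here means a stronger inhibitor, a higher number a weaker inhibitor), where compound 2 gives 1600 nM. Its nearest neighbour, compound 1 `Cc1ccccc1COc1ccc(-c2cc(CN3CCN(Cc4ccc(C(F)(F)F)cc4)CC3)no2)cc1`, gives 3700 nM in this assay. For the measured compounds named here, the one step within the measured pair, a 2.3-fold lower number from compound 1 to compound 2 (0.36 log units; beyond the scatter), is the only one that bears on the new compound, since it also replaces one ring on the saturated chain carbon bound to the oxygen by another.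

Compound 3 `FC(F)(F)c1ccc(CN2CCN(Cc3cc(-c4ccc(OCc5cccc(Cl)c5)cc4)on3)CC2)cc1` differs from compound 2 by 3-chlorophenyl in place of 3,5-dimethylphenyl on a saturated chain carbon bound to an oxygen on an aromatic ring. Going by the values given here, no measured step exchanges a dimethyl-bearing ring for a chlorine-bearing one, so the modest step from compound 1 to compound 2 gives only the scale of change such a ring swap has produced. The expected step from compound 2 to compound 3 in this assay is therefore small, a 1.3-fold higher number from compound 2 to compound 3 (0.10 log units; within the scatter), with no clear direction. Compound 3 is estimated at 2000 nM, within a range of 800 nM to 5000 nM.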

Compound 3, half-maximal inhibitory concentration: 1400 nM
Beside the measured number, compound 3's estimate is 1.4-fold (0.15 log units) above it, within the range that was stated.
By their numbers in this assay, from the lowest: compounds 3 and 2 (each within the scatter of the next); then compound 1.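

In this assay, the change at this position gives a 1.1-fold lower number from compound 2 to compound 3 (0.06 log units; within the scatter) and so does not separate 3-chlorophenyl from 3,5-dimethylphenyl; a ring with one chlorine and a ring with two methyl groups sit at the same level here. Among the compounds shown here, the step of a 2.6-fold lower number from compound 1 to compound 3 (0.42 log units; beyond the scatter) stands beyond the scatter and shows that the separation from the 2-methylphenyl ring of compound 1 is not confined to compound 2, with no compound of the three going against this. No supporting measurement bears on the reason for either step.

Open, on these data alone, is whether a ring carrying a methoxy group, a nitrile or a carboxylic acid in place of the chlorine would stay at the level of compound 2 and compound 3. Also open, as far as these compounds go, is how a longer chain between the oxygen and the ring would read.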